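Chloro for Methoxy on the Thiazole-Linked Aryl Ring

The source may hold more compounds than are shown below. What is called first, only, known or untested is meant among the compounds shown, and "the series" means these compounds.

Measured compounds:
compound 1 `COc1ccc(-c2nc(C)c(C(=O)CSc3nc(-c4ccc(Cl)cc4)c(C#N)c(=O)[nH]3)s2)cc1`: 2.85%
compound 2 `COc1ccc(-c2nc(C)c(C(=O)CSc3nc(-c4ccc(OC)cc4)c(C#N)c(=O)[nH]3)s2)cc1`: 11.5%
compound 3 `COc1ccc(-c2nc(C)c(C(=O)CSc3nc(-c4cccc(OC)c4)c(C#N)c(=O)[nH]3)s2)cc1`: 12.4%

In a functional assay on U-87MG ATCC cells for antiproliferative activity against U-87 MG (Homo sapiens), read by MTT assay, with a stated time of 48 h, tested at 100 uM (a higher number here means a weaker effect of the compound at the concentration tested, a lower number a stronger effect), compound 1 gives the lowest of the three numbers, though a number 8.7 percentage points higher from compound 1 to compound 2 (within the scatter) and a number 9.6 percentage points higher from compound 1 to compound 3 (within the scatter) both lie within the scatter, so no order among them is claimed. Compound 4 `Cc1nc(-c2ccc(Cl)cc2)sc1C(=O)CSc1nc(-c2ccc(Cl)cc2)c(C#N)c(=O)[nH]1` differs from compound 1 by chloro in place of methoxy on an aromatic carbon. Among the compounds with values here, only one measured step swaps these same two groups, a number 8.7 percentage points higher from compound 1 to compound 2 (within the scatter), on the other aryl ring, and it stayed within the scatter. Within the data shown here, no step touches this ring itself. The expected step of a number 2.2 percentage points higher from compound 1 to compound 4 (within the scatter) in this assay is therefore none beyond the scatter. Compound 4 is estimated at 5%, in the range 0% to 16%.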

Compound 4, a percentage reported as activity, at one concentration (the size of the read-out at that concentration, not a potency): 12.8%
For compound 4 the middle estimate is 7.8 percentage points below the measured one, within the range that was stated.
By their numbers in this assay, from the lowest: compounds 1, 2, 3 and 4 (each within the scatter of the next).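

Chloro in place of methoxy on this ring, para to a large group, now has a measured step of its own in this assay: a number 10 percentage points higher from compound 1 to compound 4 (within the scatter). This swap of the two groups has therefore stayed within the scatter on both aryl rings, so the position shows no measurable sensitivity to it so far. Nothing available gives a reason for this result. Going by these compounds, whether an amine or a carboxylic acid on this ring would give a step beyond the scatter remains open.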